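The source may report more compounds than this note shows. Statements on the series, on what has been measured and on what is new or still open speak of the compounds shown alone.

Working notes on the series. For the measured compounds named here, compound 1 `COc1cc(-c2nn(-c3cccc(NC(=O)Nc4cc(C(F)(F)F)cc(C(F)(F)F)c4)c3)cc2-c2ccncc2)ccc1Cl` is the only member with a number: in a functional assay on SF-295 cells (Homo sapiens) for inhibition, read by sulforhodamine B assay, with a stated time of 48 h (on this read-out lower numbers stand for stronger inhibition and higher numbers for weaker inhibition), compound 1 gives 400 nM. Compound 2 `O=C(Nc1cccc(-n2cc(-c3ccncc3)c(-c3ccc(Cl)c(O)c3)n2)c1)Nc1ccc(Cl)c(Cl)c1` belongs to the same series, but in this assay compound 2 gives "not determined" (no result reported), so nothing can be said of how the two compare, and compound 1 stands alone as the reference point.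

Compound 3 `COc1cc(-c2nn(-c3cccc(NC(=O)Nc4cccc(C(F)(F)F)c4)c3)cc2-c2ccncc2)ccc1Cl` is the next entry and is still to be measured. It differs from compound 1 in one place: hydrogen in place of trifluoromethyl on an aromatic carbon. Going by the values given here, no pair of measured compounds shows a step of this kind, so the size has to be guessed. The expectation is a modest loss of inhibition, a 2.0-fold higher number from compound 1 to compound 3 (0.30 log units; within the scatter), not far beyond the usual scatter. For compound 3 in this assay the estimate is 800 nM, with a range from 300 nM to 2500 nM.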

Compound 3, half-maximal inhibitory concentration: 310 nM
Estimate against measurement, compound 3: 2.6-fold (0.41 log units) above, within the range that was stated.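

In this assay the swap of hydrogen for trifluoromethyl on this aromatic carbon gives a 1.3-fold lower number from compound 1 to compound 3 (0.11 log units; within the scatter) and so separates the two compounds by no more than the usual scatter. For the compounds shown here, this is the first step read, and it shows that this position can lose a group of 4 heavy atoms, while the other trifluoromethyl group stays in place, without a step beyond the scatter. Nothing at hand explains this result.

The compounds shown leave open whether the remaining trifluoromethyl group can also give way to hydrogen without a step beyond the scatter. They also leave open how an amine or a carboxylic acid on this same aromatic carbon would read out.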